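The source may hold more compounds than are shown below. What is called first, only, known or untested is meant among the compounds shown, and "the series" means these compounds.

Two compounds of this series have been run in an ADME assay on PC-3 cells (Homo sapiens) for cytotoxicity, read by WST assay, tested at 100 uM; on this read-out lower numbers stand for less inhibition and higher numbers for more inhibition at the one concentration tested (going by the name of the read-out). Compound 1 `CCc1cccc(NC(=O)C2CCCN(C(=O)c3cc(C(F)(F)F)cc(C(F)(F)F)c3)C2)c1` gives 0% in this assay. Compound 2 `C=Cc1cccc(C(=O)N2CCCC(C(=O)Nc3ccc(Cl)cc3)C2)c1` gives 0% in this assay. The two values are level at the digits shown and lie within the scatter of each other, so compound 1 stands at the floor of the read-out alongside compound 2, with no inhibition seen for either.

Compound 3 `COc1cccc(NC(=O)C2CCCN(C(=O)c3cc(C(F)(F)F)cc(C(F)(F)F)c3)C2)c1` has not yet been measured in this assay. It differs from compound 1 by methoxy in place of ethyl on an aromatic carbon. Within the data shown here, no pair of measured compounds differing in a single place is available, so the size of such a change in this assay is unknown from the data. Both measured compounds sit at the floor, which gives no hint of a rise. The step is expected to be none beyond the scatter, no change at the digits printed from compound 1 to compound 3 (within the scatter). Compound 3 is estimated at 0%, with a range from -8% to 12%.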

Compound 3, a percentage reported as inhibition, at one concentration (the size of the read-out at that concentration, not a potency): 0%
Compound 3: middle estimate and measured number agree at the digits printed; low and high end bracket the measured number.
By their numbers in this assay, from the lowest: compounds 1, 2 and 3 (each within the scatter of the next).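

In this assay, among these compounds, the change from 3-ethylphenyl to 3-methoxyphenyl provides the only single-place comparison, and it reads as no change at the digits printed from compound 1 to compound 3 (within the scatter) for methoxy in place of ethyl on an aromatic carbon. At this place, meta to a large group, the exchange of ethyl for methoxy introduces oxygen and a hydrogen-bond acceptor with no rise off the floor of the read-out, although a floor value cannot reveal any effect that stays hidden there. No supporting data are available to explain this result.

As far as these compounds go, whether an amine, a carboxylic acid or a longer chain at this position would give measurable inhibition at the one concentration tested remains open. With all three compounds at the floor, the shown set also leaves unknown which parts of the shared core can move this read-out at all.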